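The source may report more compounds than this note shows. Statements on the series, on what has been measured and on what is new or still open speak of the compounds shown alone.

Working notes on the series. Three compounds share one core and differ only in the group on the ring nitrogen of the five-membered ring. Compound 1 `O[C@H](COCCOC[C@@H](O)Cc1cn(Cc2ccc(Oc3ccccc3)cc2)nn1)Cc1ccc(-c2ccccc2)cc1` gives 4500 nM in a functional assay on SGC-7901 cells (Homo sapiens) for inhibition, read by MTT assay, with a stated time of 72 h; a higher number here means a weaker inhibitor of growth, a lower number a stronger inhibitor of growth. Compound 2 `O[C@H](COCCOC[C@@H](O)Cc1cn(Cc2ccc(C(F)(F)F)cc2)nn1)Cc1ccc(-c2ccccc2)cc1` gives 8700 nM, and compound 3 `COC1=C(OC)C(=O)C(CCCCCCn2cc(C[C@H](O)COCCOC[C@@H](O)Cc3ccc(-c4ccccc4)cc3)nn2)=C(C)C1=O` gives 16700 nM. On these three numbers compound 2 sits second highest, within the scatter of both neighbours. Among the measured compounds shown here, the only one-place step available, a 1.9-fold higher number from compound 1 to compound 2 (0.29 log units; within the scatter), stays within the scatter, so no substituent effect at this position has yet been resolved.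

Compound 4 `O[C@H](COCCOC[C@@H](O)Cc1cn(-c2cncc3ccccc23)nn1)Cc1ccc(-c2ccccc2)cc1` is not yet measured. Relative to compound 2 the change is isoquinolin-4-yl in place of 4-(trifluoromethyl)benzyl on an aromatic nitrogen. For the measured compounds named here, no measured step bears directly on this change: the step from compound 1 to compound 2 exchanges groups on the benzyl ring, whereas here the whole benzyl group is replaced, and compound 3 carries an unrelated chain at this position. Given that all three measured values lie within the scatter of one another, compound 4 is expected to stay near this band, with a 1.2-fold lower number from compound 2 to compound 4 (0.06 log units; within the scatter) as the estimated step. The value of compound 4 is estimated at 7500 nM, within 2500 nM to 25000 nM.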

Compound 4, concentration for 50% growth inhibition: 29300 nM
Estimate against measurement, compound 4: 3.9-fold (0.59 log units) below; the measured number lies above the stated range.
By their numbers in this assay, from the lowest: compounds 1, 2, 3 and 4 (each within the scatter of the next, the first and the last beyond it).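

In this assay, among the compounds shown here, isoquinolin-4-yl in place of 4-(trifluoromethyl)benzyl gives a 3.4-fold higher number from compound 2 to compound 4 (0.53 log units; beyond the scatter) and is the first one-place step to clear the scatter, so the group on this aromatic nitrogen can move the number, if only modestly. The exchange alters several things at once: the benzyl carbon and the trifluoromethyl leave, while a ring with one hetero atom and one hydrogen-bond acceptor enter, so the step cannot be assigned to any single feature. Nothing on hand accounts for the step.

Going by these compounds, it remains open whether the step follows from losing the benzyl carbon or from the isoquinolin-4-yl group itself, a distinction that an isoquinolin-4-ylmethyl group would address. Also open, on these data alone, is how an amine or a carboxylic acid on the benzyl ring would compare with compound 2.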